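The compounds below may be only part of what the source reports. "The series", "measured", "known", "first", "only" and "open" are said of these compounds alone.

In a physicochemical assay for solubility, read by chemiluminescence (a higher number here means a more soluble compound, a lower number a less soluble compound), compound 2 (`O=C(CN(C(=O)C1CCOCC1)C1CCCCC1)Nc1cc(F)cc(F)c1`) reads 127 ug/mL and compound 1 (`CN1CCC(C(=O)N(CC(=O)Nc2cc(F)cc(F)c2)C2CCCCC2)CC1`) reads 140 ug/mL so the two stand level within the scatter. Compound 3 (`O=C(CN(C(=O)c1cccnc1)C1CCCCC1)Nc1cc(F)cc(F)c1`), not yet measured, differs from compound 2 by pyridin-3-yl in place of oxan-4-yl on a carbonyl carbon. Within the data shown here, the one measured step at that place (a 1.1-fold lower number from compound 1 to compound 2 (0.04 log units; within the scatter)) put oxan-4-yl in place of 1-methylpiperidin-4-yl and stayed within the scatter, but it involved no aromatic ring, so it is only a loose guide. A change in this assay beyond the scatter is therefore not expected, and the estimated step (a 1.2-fold lower number from compound 2 to compound 3 (0.08 log units; within the scatter)) is small. For compound 3 the expected value is 105 ug/mL with an estimated range (50 ug/mL to 190 ug/mL).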

Compound 3, solubility: 160 ug/mL
The estimate for compound 3 lay 1.5-fold (0.18 log units) below the measured number; the measured number falls inside the stated range.
By their numbers in this assay, from the lowest: compounds 2, 1 and 3 (each within the scatter of the next).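

In this assay, an aromatic ring on this carbonyl carbon now has a reading: pyridin-3-yl in place of oxan-4-yl gives a 1.3-fold higher number from compound 2 to compound 3 (0.10 log units; within the scatter) and pyridin-3-yl in place of 1-methylpiperidin-4-yl gives a 1.1-fold higher number from compound 1 to compound 3 (0.06 log units; within the scatter). Both steps lie within the scatter, so compounds 1, 2 and 3 stand level whether the ring at this place is aromatic or not. Nothing available explains this level reading. Still open, from the compounds shown here alone, is whether a different group on that carbonyl carbon, such as a carboxylic acid or a longer chain, would move the number beyond the scatter.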